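The compounds below may be only part of what the source reports. "The series", "measured", "known", "first", "only" and "open" are said of these compounds alone.

Compound 2 `Cc1ccc(OC2CCN(c3ccc(-n4ccnc4)nn3)CC2)cc1` gives 527 nM in an assay on microsomes from liver for inhibition of acyl-CoA desaturase 1 (Rattus norvegicus) (a higher number here means a weaker inhibitor, a lower number a stronger inhibitor), the highest of the three numbers in hand. Compound 1 `Brc1ccccc1OC1CCN(c2ccc(-n3ccnc3)nn2)CC1` gives 5 nM in this assay, and compound 3 `c1cn(-c2ccc(N3CCC(Oc4ccc5c(c4)CCC5)CC3)nn2)cn1` gives 62 nM. The steps among them run as follows: a 110-fold higher number from compound 1 to compound 2 (2.02 log units; beyond the scatter); a 12-fold higher number from compound 1 to compound 3 (1.09 log units; beyond the scatter); an 8.5-fold lower number from compound 2 to compound 3 (0.93 log units; beyond the scatter). Each of these replaces the whole aryl group on the oxygen on the saturated carbon; none keeps the ring and alters only one substituent on it.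

Compound 4 `FC(F)(F)c1ccc(OC2CCN(c3ccc(-n4ccnc4)nn3)CC2)cc1` differs from compound 2 by trifluoromethyl in place of methyl on an aromatic carbon. Within the data shown here, no measured step is of this kind, so nothing bears on it directly; the measured steps show only that the aryl group on the oxygen moves the number over a wide span, which leaves the uncertainty broad. For compound 4 a step of a 1.2-fold lower number from compound 2 to compound 4 (0.07 log units; within the scatter) is expected, not beyond the scatter. The estimate for compound 4 is 450 nM, with a range from 120 nM to 1700 nM.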

Compound 4, half-maximal inhibitory concentration: 371 nM
Compound 4: the middle estimate sits 1.2-fold (0.08 log units) above what was measured, and the stated range covers the measured number.
By their numbers in this assay, from the lowest: compound 1; then compound 3; then compounds 4 and 2 (each within the scatter of the next).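

Trifluoromethyl in place of methyl, on an aromatic carbon para to a large group, gives a 1.4-fold lower number from compound 2 to compound 4 (0.15 log units; within the scatter) in this assay; this is the only step shown that keeps the aryl ring and alters one substituent on it. Going from one heavy atom to four at this place therefore leaves the number within the scatter, whereas replacing the whole aryl group gave a 110-fold higher number from compound 1 to compound 2 (2.02 log units; beyond the scatter) and thus a far larger change. Nothing measured here offers a reason for this pair's close values.

The compounds shown leave open whether the result extends to other groups at this place, such as an amine or a carboxylic acid. They also leave open whether bromine at this same place would come near the number of compound 1 (5 nM) or stay near the numbers of the pair just compared.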